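This account rests on a few compounds, and the source may have more. Where it says the series, first, only, none or still open, it means among the compounds named here.

Three compounds on one shared core differ only in the group on a saturated chain carbon bound to a carbonyl carbon. In a functional assay on MCF7 cells (Homo sapiens) for antiproliferative activity, read by MTT assay, with a stated time of 48 h (on this read-out higher numbers stand for weaker inhibition and lower numbers for stronger inhibition), compound 1 (`COc1ccc(C(=O)c2ccc3c(c2)C=CC(C)(C)O3)c(NC(=O)CBr)c1`), the bromo member, gives 2880 nM. Compound 2 (`COc1ccc(C(=O)c2ccc3c(c2)C=CC(C)(C)O3)c(NC(=O)CN)c1`), the amino member, gives 680 nM, and compound 3 (`CNCC(=O)Nc1cc(OC)ccc1C(=O)c1ccc2c(c1)C=CC(C)(C)O2`), the methylamino member, gives 1210 nM. Compound 3 stands apart from the bromo member, with a 2.4-fold lower number from compound 1 to compound 3 (0.38 log units; beyond the scatter), but not from the amino member, with a 1.8-fold higher number from compound 2 to compound 3 (0.25 log units; within the scatter), which lies within the scatter.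

The next compound is compound 4 (`COc1ccc(C(=O)c2ccc3c(c2)C=CC(C)(C)O3)c(NC(=O)CN(C)C)c1`), and the change is methyl in place of hydrogen on an amine nitrogen, so methylamino becomes dimethylamino. The closest precedent is the same replacement made once already, the step to compound 3 from compound 2 given above. It is a single example and did not clear the scatter. The larger 4.2-fold lower number from compound 1 to compound 2 (0.63 log units; beyond the scatter) replaces bromo and says little about methyl on the nitrogen.

No step beyond the scatter is therefore expected in this assay, with only a slight lean towards a higher number. The expected change is a 1.2-fold higher number from compound 3 to compound 4 (0.09 log units; within the scatter). Compound 4 is estimated at 1500 nM, with an expected range from 700 nM to 3000 nM.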

Compound 4, half-maximal inhibitory concentration: 3560 nM
For compound 4 the middle estimate is 2.4-fold (0.38 log units) below the measured one; measured number outside the range, above it.
By their numbers in this assay, from the lowest: compounds 2 and 3 (each within the scatter of the next); then compounds 1 and 4 (each within the scatter of the next).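

In this assay, methyl on this amine nitrogen now registers: the second methyl gives a 2.9-fold higher number from compound 3 to compound 4 (0.47 log units; beyond the scatter) and clears the scatter, whereas the first gave a 1.8-fold higher number from compound 2 to compound 3 (0.25 log units; within the scatter) and did not. Taken as a whole, the change from amino to dimethylamino on the saturated chain carbon bound to a carbonyl carbon gives a 5.2-fold higher number from compound 2 to compound 4 (0.72 log units; beyond the scatter) and separates the two members clearly, while the step from bromo to dimethylamino gives a 1.2-fold higher number from compound 1 to compound 4 (0.09 log units; within the scatter) and stays within the scatter, so a nitrogen group at this position does not by itself separate a compound from the bromo member. Nothing in hand explains why the second methyl differs from the first.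

The three nitrogen members leave open whether the higher number follows the loss of the last hydrogen on the nitrogen or the number of carbons placed on it. Ethylamino, diethylamino and a ring amine such as pyrrolidine or morpholine at the same carbon would begin to separate these two readings.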